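Working notes: one further hydroxy on compound 1

This account rests on a few compounds, and the source may have more. Where it says the series, first, only, none or still open, it means among the compounds named here.

Compound 1 `Cn1c(/C=C/C(=O)c2ccccc2O)cc(Br)c1Br`: 2510 nM
Compound 2 `Cn1c(/C=C/C(=O)c2ccccc2)cc(Br)c1Br`: 35400 nM

Among the compounds with values here, in a functional assay on MCF7 cells (Homo sapiens) for cytotoxicity, read by MTT assay, with stated times of 6 h and 48 h (a lower number here means a stronger inhibitor, a higher number a weaker inhibitor), compound 1 holds the lower of the two numbers so far. The next step leads to compound 3 `Cn1c(/C=C/C(=O)c2ccc(O)cc2O)cc(Br)c1Br`, still unmeasured: hydroxy in place of hydrogen on an aromatic carbon, meta to a hydroxy group and para to a large group. Within the data shown here, one measured step bears on this, and only indirectly: a 14-fold higher number from compound 1 to compound 2 (1.15 log units; beyond the scatter), a large step in which hydrogen takes the place of hydroxy. Among the measured compounds shown here, that step concerns the existing hydroxy, not the carbon changed here, and no measured compound carries a second hydroxy. A much smaller move towards a lower number is therefore expected in this assay, possibly none beyond the scatter. The expected change is a 1.4-fold lower number from compound 1 to compound 3 (0.14 log units; within the scatter). For compound 3 the estimated value is 1800 nM, with an expected range of 500 nM to 7000 nM.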

Compound 3, half-maximal inhibitory concentration: 1610 nM
Estimate against measurement, compound 3: 1.1-fold (0.05 log units) above; the measured number falls inside the stated range.
By their numbers in this assay, from the lowest: compounds 3 and 1 (each within the scatter of the next); then compound 2.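

In this assay, the carbon meta to a hydroxy group and para to a large group takes a hydroxy in place of hydrogen with only a 1.6-fold lower number from compound 1 to compound 3 (0.19 log units; within the scatter), so this change adds nothing beyond the scatter. The hydroxy already present on compound 1 behaves differently: replacing it with hydrogen gives a 14-fold higher number from compound 1 to compound 2 (1.15 log units; beyond the scatter), so in this pair of steps, the two hydroxy positions do not carry equal weight. Nothing available explains this difference between the two positions.

Still open, going by these compounds, is whether this carbon tolerates other groups, such as a methoxy, an amine or a carboxylic acid, as well as it tolerates hydroxy. Also open, on these data alone, is whether a hydroxy here would give any step in a compound lacking the hydroxy of compound 1, since the new hydroxy has been seen only alongside that one.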